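A Fluoro for Hydrogen Swap on the Phenyl Ring

A few compounds are considered here, and "the series" means these few. Any claim that something is new, unique, unknown or untested is made for them only; others in the source may bear on it.

compound 1 `Cc1ccc([C@@H]2CN(C)[C@]3(C(=O)Nc4ccccc43)[C@]23Cc2ccccc2C3=O)cc1`: 56.4%
compound 2 `CN1C[C@@H](c2ccccc2)[C@@]2(Cc3ccccc3C2=O)[C@@]12C(=O)Nc1ccccc12`: 56%

Both numbers come from a functional assay on the whole organism (strain Wister albino) for inhibition, with Rattus norvegicus as the target, read by paw edema, with a stated time of 1 h, at a dose of 50 mg/kg by the intraperitoneal route; a lower number here means less inhibition, a higher number more inhibition at the dose given (going by the name of the read-out). Among the compounds with values here, compound 2 stands lowest of the two, with compound 1 its nearest neighbour within the scatter; the single measured step, a number 0.4 percentage points lower from compound 1 to compound 2 (within the scatter), was within the scatter. Compound 3 `CN1C[C@@H](c2ccc(F)cc2)[C@@]2(Cc3ccccc3C2=O)[C@@]12C(=O)Nc1ccccc12` differs from compound 2 by fluoro in place of hydrogen on an aromatic carbon. Within the data shown here, only that one step bears on this change, and it was within the scatter, so the step expected is no change at the digits printed from compound 2 to compound 3 (within the scatter), nothing beyond the scatter. Compound 3 is therefore estimated at 56%, with a range from 46% to 66%.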

Compound 3, a percentage reported as inhibition, in the whole organism at one dose (the size of the read-out at that dose, not a potency): 40.6%
Estimate against measurement, compound 3: 15.4 percentage points above; the measured number lies below the stated range.
By their numbers in this assay, from the lowest: compound 3; then compounds 2 and 1 (each within the scatter of the next).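

In this assay this place on the ring, para to a large group, had not separated hydrogen from methyl, yet it does respond to fluoro: the swap for hydrogen gives a number 15.4 percentage points lower from compound 2 to compound 3 (beyond the scatter) and the swap for methyl gives a number 15.8 percentage points lower from compound 1 to compound 3 (beyond the scatter) at the same place. The place is therefore not indifferent to what sits on it, and among these three groups only fluoro stands apart. As far as these compounds go, whether chloro, methoxy or an amine there would go the way of fluoro or of methyl stays open. Nothing at hand accounts for the fall.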